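Acyl variation on the benzimidazole amide series

The source may hold more compounds than are shown below. What is called first, only, known or untested is meant among the compounds shown, and "the series" means these compounds.

Compound 3 `COc1ccc([N+](=O)[O-])cc1CSc1nc2cc(NC(=O)C3CCC3)ccc2n1C(C)C` gives 1500 nM in an assay on isolated protein for inhibition of Gonadotropin-releasing hormone receptor (Homo sapiens) (on this read-out higher numbers stand for weaker inhibition and lower numbers for stronger inhibition), the highest of the three numbers measured. Its nearest neighbour is compound 2 `COc1ccc([N+](=O)[O-])cc1CSc1nc2cc(NC(=O)OC(C)(C)C)ccc2n1C(C)C` with 880 nM in this assay; the step of a 1.7-fold higher number from compound 2 to compound 3 (0.23 log units; within the scatter) changes nothing that can be trusted. The furthest is compound 1 `COc1ccc([N+](=O)[O-])cc1CSc1nc2cc(NC(=O)NC(C)(C)C)ccc2n1Cc1ccncc1` with 47 nM in this assay, but compound 1 differs from compound 3 in two places and offers no single-point comparison.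

Compound 4 `COc1ccc([N+](=O)[O-])cc1CSc1nc2cc(NC(=O)C(C)(C)C)ccc2n1C(C)C` carries tert-butyl in place of cyclobutyl on a carbonyl carbon. Within the data shown here, only one measured step bears on the acyl position, namely a 1.7-fold higher number from compound 2 to compound 3 (0.23 log units; within the scatter), a swap at the same carbonyl carbon that stayed inside the scatter. The tert-butyl of compound 4 also appears in compound 1, attached there through a urea nitrogen rather than directly, and alongside a different substituent on the shared core, so the low number of compound 1 cannot be carried over.

The expected step of a 1.3-fold lower number from compound 3 to compound 4 (0.10 log units; within the scatter) in this assay is therefore small, with no direction beyond the scatter. Compound 4 is estimated at 1200 nM in this assay, expected between 450 nM and 3200 nM.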

Compound 4, half-maximal inhibitory concentration: 180 nM
The estimate for compound 4 lay 6.7-fold (0.82 log units) above the measured number; measured number outside the range, below it.
By their numbers in this assay, from the lowest: compound 1; then compound 4; then compounds 2 and 3 (each within the scatter of the next).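

In this assay, the acyl position proves responsive to a swap that keeps the count at 4 heavy atoms, all carbon: tert-butyl in place of cyclobutyl on the carbonyl carbon, an open group for a four-membered ring, gives an 8.3-fold lower number from compound 3 to compound 4 (0.92 log units; beyond the scatter). Compound 4 also separates from the tert-butoxy carbonyl of compound 2, with a 4.9-fold lower number from compound 2 to compound 4 (0.69 log units; beyond the scatter), whereas cyclobutyl in place of tert-butoxy gave only a 1.7-fold higher number from compound 2 to compound 3 (0.23 log units; within the scatter), so in this small set the tert-butyl on the carbonyl carbon stands apart from both other groups. The data at hand offer no measurement that accounts for this difference.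

Going by these compounds, whether the lower number is specific to tert-butyl remains open, since an isopropyl group, a cyclopropyl ring or a longer chain on the carbonyl carbon would be needed to test it. On these data alone, how a basic amine at the end of such a chain would read in this assay also remains open.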